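This account rests on a few compounds, and the source may have more. Where it says the series, first, only, none or still open, it means among the compounds named here.

Measured so far:
Compound 1 `COc1ccc(-c2cc(/C=C/C(=O)c3ccc(OC)c(OC)c3)[nH]n2)cc1` gives 5150 nM
Compound 2 `COc1cc(-c2cc(/C=C/C(=O)c3ccc(Cl)c(Cl)c3)[nH]n2)cc(OC)c1OC` gives 15700 nM

Both numbers come from a functional assay on T47D cells (Homo sapiens) for inhibition, read by sulforhodamine B assay, with a stated time of 48 h; on this read-out lower numbers stand for stronger inhibition of growth and higher numbers for weaker inhibition of growth. Among the compounds with values here, of the two, compound 2 stands at the highest number, and compound 1, the only other measured compound, gives a lower number; that gap lies beyond the usual scatter of repeated measurements, so compound 2 is the weaker of the two on this assay.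

Compound 3 `COc1ccc(C(=O)/C=C/c2cc(-c3cc(OC)c(OC)c(OC)c3)n[nH]2)cc1OC` has not yet been measured. It is built from compound 2 by one change: 3,4-dimethoxyphenyl in place of 3,4-dichlorophenyl on a carbonyl carbon. Within the data shown here, the part that enters is the same group that compound 1 carries on its carbonyl carbon, although compound 1 differs from compound 3 elsewhere as well, so no direct step between measured compounds tells how this change alone plays out.

Among the measured compounds shown here, with only two measured compounds, the expectation rests on compound 1, which gives 5150 nM while carrying the 3,4-dimethoxyphenyl group. Compound 3 is therefore expected to move toward a lower number, with the step of a 2.4-fold lower number from compound 2 to compound 3 (0.38 log units; beyond the scatter) estimated as modest but beyond the scatter. The estimate for compound 3 is 6500 nM, with a range from 2500 nM to 17000 nM.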

Compound 3, concentration for total growth inhibition: 4360 nM
Beside the measured number, compound 3's estimate is 1.5-fold (0.17 log units) above it, and the stated range covers the measured number.
By their numbers in this assay, from the lowest: compounds 3 and 1 (each within the scatter of the next); then compound 2.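

With the rest of the molecule unchanged, this assay responds to the ring on the carbonyl carbon: placing 3,4-dimethoxyphenyl there instead of 3,4-dichlorophenyl gives a 3.6-fold lower number from compound 2 to compound 3 (0.56 log units; beyond the scatter) as a modest step beyond the usual scatter. The earlier pair could not show this, since those two compounds differ in more than one place and the effect of this ring could not be separated from the other difference. The new pair isolates the change and shows that, on this core, the dimethoxy-bearing ring goes with stronger inhibition of growth than the dichloro-bearing ring, though a single pair establishes no wider pattern.

From the compounds shown here alone, whether another group on a carbonyl carbon, such as a simple phenyl, a pyridine ring, or a phenyl carrying a hydroxyl or a dimethylamino group, would give a lower or a higher number remains open. Nothing available explains why the swap moves the number, and the step can be reported only as an observed difference in growth inhibition.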